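Dichloro analogue in a keratinocyte cytotoxicity screen

This account rests on a few compounds, and the source may have more. Where it says the series, first, only, none or still open, it means among the compounds named here.

Compound 1 `c1ccc(-c2nn(-c3ccccc3)cc2-c2nc3ccccc3[nH]2)cc1`: in an ADME assay on HaCaT cells (Homo sapiens) for cytotoxicity, read by MTT assay, with a stated time of 48 h (a higher number here means a weaker inhibitor, a lower number a stronger inhibitor), compound 1 gives > 50000 nM, which is a limit of the assay rather than a number.
Compound 2 `Clc1ccc(-c2nn(-c3ccccc3)cc2-c2nc3ccccc3[nH]2)cc1`: in this assay compound 2 gives > 50000 nM, also a limit.
Compound 3 `COc1ccc(-c2nn(-c3ccccc3)cc2-c2nc3cc(Cl)ccc3[nH]2)cc1`: in this assay compound 3 gives > 50000 nM, again a limit.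

The change chloro in place of hydrogen on an aromatic carbon made a step that the two limits leave unreadable from compound 1 to compound 2; its size cannot be read because of the limit of > 50000 nM in this assay, at which 3 of the 3 values shown sit. The difference between the cores of compound 1 and compound 3 is not broken down here. Compound 4 `COc1ccc(-c2nn(-c3ccccc3)cc2-c2nc3cc(Cl)c(Cl)cc3[nH]2)cc1` is not yet measured and differs from compound 3 by chloro in place of hydrogen on an aromatic carbon. Here the place reads part of a fused or bridged system of two rings, ortho to a chloro group, meta to a fused ring and para to a fused ring, rather than para to a large group, so this is the same kind of change, not the same. The step from compound 3 to compound 4 is expected to be a step that the limit leaves unreadable from compound 3 to compound 4, because the limit of > 50000 nM in this assay, at which 3 of the 3 values shown sit, gives no sign of any movement. Compound 4 is estimated at 80000 nM.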

Compound 4, half-maximal inhibitory concentration: > 50000 nM
Compound 4: only a limit was reported; the forecaster's own chance of this, stated with the estimate: 85%; the middle value lies beyond the limit too.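

The step from compound 3 to compound 4 cannot be read, because both values are limits rather than numbers: the limit of > 50000 nM in this assay, at which 4 of the 4 values shown sit.

The compounds shown leave open at what concentration any of them would harm these cells, and whether the added chloro changes that at all.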